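Benzofuran series: phenol analogue of compound 2

The compounds below may be only part of what the source reports. "The series", "measured", "known", "first", "only" and "open" are said of these compounds alone.

Going by the values given here, compound 2 `COc1cc(OCc2cccc(COc3ccccc3)c2)c2cc(-c3cn4nc(OC)sc4n3)oc2c1` and compound 1 `COc1cc(OCc2ccccc2OC)c2cc(-c3cn4nc(OC)sc4n3)oc2c1` are the two compounds measured so far. In an ADME assay on microsomes from liver (Homo sapiens) for metabolic stability, with a stated time of 10 min (on this read-out lower numbers stand for a less stable compound and higher numbers for a more stable compound), compound 2 gives 86%, and compound 1 gives 82%; the two values lie within the scatter of each other, so compound 2 stands alongside compound 1 rather than apart from it. Compound 3 `COc1cc(OCc2cccc(O)c2)c2cc(-c3cn4nc(OC)sc4n3)oc2c1` has not yet been measured in this assay. It differs from compound 2 by hydroxy in place of phenoxymethyl on an aromatic carbon. Among the compounds with values here, no step between measured compounds covers this kind of change, so the expectation rests on compound 2 alone. The step from compound 2 to compound 3 is expected to be small, a number 6 percentage points lower from compound 2 to compound 3 (within the scatter), and not beyond the scatter. For compound 3 the estimate in this assay is 80%, with a range from 62% to 95%.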

Compound 3, percent of the compound remaining: 97%
Compound 3: the middle estimate sits 17 percentage points below what was measured; the whole stated range lies below it.
By their numbers in this assay, from the lowest: compounds 1 and 2 (each within the scatter of the next); then compound 3.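

Compound 1 and compound 2 alone, within the scatter of each other, gave no sign that this side of the molecule moves the read-out, but in this assay hydroxy in place of phenoxymethyl gives a number 11 percentage points higher from compound 2 to compound 3 (beyond the scatter). The change of 2-methoxyphenyl to 3-hydroxyphenyl gives a number 15 percentage points higher from compound 1 to compound 3 (beyond the scatter), so the large phenoxymethyl group is not required here for a high number. No measured data explain this rise. Still open, from the compounds shown here alone, is whether the hydroxy itself or the loss of phenoxymethyl carries the step, and how an amine or a carboxylic acid on the same aromatic carbon would read.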